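This account rests on a few compounds, and the source may have more. Where it says the series, first, only, none or still open, it means among the compounds named here.

Among the compounds with values here, in a functional assay on THP-1 cells (Homo sapiens) for inhibition, read by sulforhodamine B assay, with a stated time of 48 h (on this read-out lower numbers stand for stronger inhibition and higher numbers for weaker inhibition), compound 2 (`Cc1ccc2occ([C@@H]3C[C@H](OCC(C)C)ON3c3ccccc3)c(=O)c2c1`) gives 21500 nM, the only actual number so far. Compound 1 (`O=c1c([C@@H]2C[C@H](c3ccccc3)ON2c2ccccc2)coc2ccccc12`), which also carries a phenyl group, gives > 60000 nM, and this is a limit of the assay, not a number. Compound 3 (`Cc1ccc2occ([C@@H]3C[C@H](c4ccccc4)ON3c3ccccc3)c(=O)c2c1`) has phenyl in place of isobutoxy on a saturated ring carbon of the core of compound 2 (phenyl in place of isobutoxy on a saturated ring carbon). Within the data shown here, no measured pair shows this change, and the only guide is compound 1 with its limit of > 60000 nM, so a modest weakening is expected in this assay. The expected change is a 1.6-fold higher number from compound 2 to compound 3 (0.21 log units; within the scatter). For compound 3 the estimated value is 35000 nM, within an expected range of 14000 nM to 90000 nM.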

Compound 3, half-maximal inhibitory concentration: > 60000 nM
Compound 3: a limit, no number; the forecaster's own chance of this, stated with the estimate: 40%; at least 1.7-fold (0.23 log units) between middle value and limit.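

Within the data shown here, compound 2 and compound 3 give the first reading of this change on the saturated ring carbon next to the ring oxygen: in this assay, phenyl in place of isobutoxy gives an at least 2.7-fold higher number from compound 2 to compound 3 (0.44 log units; beyond the scatter). The value of compound 3, > 60000 nM, is a limit and not a number. The step between compound 1 and compound 3 cannot be read, because both values are limits: the limit of > 60000 nM in this assay, at which 2 of the 3 values shown sit.

On these data alone, whether a longer alkoxy chain or an amine at this carbon would give a lower number than compound 2 remains open. Also open, as far as these compounds go, is what the methyl group contributes on the aromatic carbon.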